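Fluoro on the anilino ring: compound 2 to compound 3

A few compounds are considered here, and "the series" means these few. Any claim that something is new, unique, unknown or untested is made for them only; others in the source may bear on it.

Measured in a functional assay on A549 cells (Homo sapiens) for inhibition, read by MTT assay, with a stated time of 72 h, tested at 10 uM; on this read-out higher numbers stand for more inhibition at the one concentration tested (going by the name of the read-out) and lower numbers for less inhibition:
compound 1 `CCOC(=O)C1=C(Nc2ccccc2)S/C(=C\c2ccc(C(=O)O)cc2)C1=O` gives 11.6%
compound 2 `CCOC(=O)C1=C(Nc2ccccc2)S/C(=C\c2ccc[nH]2)C1=O` gives 23.5%

For the measured compounds named here, compound 2 stands highest of the two numbers in this assay; the only measured step, a number 11.9 percentage points higher from compound 1 to compound 2 (beyond the scatter), lies beyond the scatter and concerns the ring on the double-bonded chain carbon. Compound 3 `CCOC(=O)C1=C(Nc2ccc(F)cc2)S/C(=C\c2ccc[nH]2)C1=O` differs from compound 2 by fluoro in place of hydrogen on an aromatic carbon. No measured step touches the anilino ring, so nothing shown bears on this change; a step of no more than the scatter is expected in this assay. For compound 3 the estimate is 25%, range 10% to 42%. The expected step is a number 1.5 percentage points higher from compound 2 to compound 3 (within the scatter).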

Compound 3, a percentage reported as inhibition, at one concentration (the size of the read-out at that concentration, not a potency): < 10%
Compound 3 ended at the assay's limit; the forecaster's own chance of this, stated with the estimate: 2%; middle value at least 15 percentage points away from the limit.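

Fluoro in place of hydrogen on the anilino ring, para to a large group, brings a number at least 13.5 percentage points lower from compound 2 to compound 3 (beyond the scatter), so this ring, untouched by the earlier step, is a position where one added heavy atom shifts the read-out beyond the scatter. Compound 3 gives < 10%, which is a limit of the assay and not a number: the limit of < 10% in this assay, at which 1 of the 3 values shown sits.

Whether the drop belongs to fluoro itself or to any group at this place stays open; only hydrogen and fluoro are shown here, and a chloro or methoxy group could separate the two. Also open, as far as these compounds go, is whether the same change holds with 4-carboxyphenyl in place of 1H-pyrrol-2-yl.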